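The compounds below may be only part of what the source reports. "The series", "measured", "known", "first", "only" and "open" are said of these compounds alone.

Three compounds share one core. Compound 1 `CCC(C)NC(=O)[C@H]1OC(n2cnc3c(N)ncnc32)[C@H](O)[C@@H]1O` carries a sec-butyl group on an amide-type nitrogen and in an assay on cell membranes for binding affinity to 2-oxoglutarate receptor 1 (Rattus norvegicus), read by radioligand binding (a lower number here means a stronger inhibitor, a higher number a weaker inhibitor), compound 1 gives 198 nM. Compound 2 `CC1CCCCC1NC(=O)[C@H]1OC(n2cnc3c(N)ncnc32)[C@H](O)[C@@H]1O` carries a 2-methylcyclohexyl group there, and in this assay compound 2 gives 69.5 nM. Compound 3 `Nc1ncnc2c1ncn2C1O[C@H](C(=O)NO)[C@@H](O)[C@H]1O` carries a hydroxy group on that nitrogen, and in this assay compound 3 gives 41 nM, the lowest of the three numbers; its gap to compound 2 is within the scatter, so no order between them can be claimed, while the step of a 4.8-fold lower number from compound 1 to compound 3 (0.68 log units; beyond the scatter) is beyond it.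

Compound 4 `CC(C)CONC(=O)[C@H]1OC(n2cnc3c(N)ncnc32)[C@H](O)[C@@H]1O` differs from compound 3 by isobutyl in place of hydrogen on an oxygen. Going by the values given here, the measured steps of a 2.8-fold lower number from compound 1 to compound 2 (0.45 log units; beyond the scatter) and a 4.8-fold lower number from compound 1 to compound 3 (0.68 log units; beyond the scatter) concern the nitrogen, and a 1.7-fold lower number from compound 2 to compound 3 (0.23 log units; within the scatter) is within the scatter; no measured step touches the oxygen. With the hydroxy group capped, the number is expected to drift back toward that of compound 1, so compound 4 is estimated at 120 nM (range 40 nM to 400 nM), a step of a 2.9-fold higher number from compound 3 to compound 4 (0.47 log units; beyond the scatter) that is expected to be modest at most.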

Compound 4, inhibition constant: 20 nM
Beside the measured number, compound 4's estimate is 6.0-fold (0.78 log units) above it, and the stated range ends above it.
By their numbers in this assay, from the lowest: compound 4; then compounds 3 and 2 (each within the scatter of the next); then compound 1.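

Placing isobutyl on the oxygen of compound 3 did not raise the number in this assay but gave a 2.1-fold lower number from compound 3 to compound 4 (0.31 log units; beyond the scatter), so the hydrogen on that oxygen is not required for a low number here and this oxygen tolerates a branched chain. The earlier compounds shown here had varied only the group on the amide-type nitrogen, and isobutoxy at that nitrogen now gives a 3.5-fold lower number from compound 2 to compound 4 (0.54 log units; beyond the scatter) and a 9.9-fold lower number from compound 1 to compound 4 (1.00 log units; beyond the scatter), which leaves compound 4 with the lowest number of the four, its steps to all the others being beyond the scatter. Nothing available explains this result.

As far as these compounds go, whether a methyl group, a straight butyl chain or a benzyl group on that oxygen would lower the number further remains open. So does whether the oxygen itself matters, which an amine at that place could test.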